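The source may report more compounds than this note shows. Statements on the series, on what has been measured and on what is new or still open speak of the compounds shown alone.

Measured compounds:
compound 1 `O=S(=O)(Nc1ccc(-c2nc3ccccc3o2)cc1)c1ccc(Cl)s1`: 31000 nM
compound 2 `O=[N+]([O-])c1cc(S(=O)(=O)Nc2ccc(-c3nc4ccccc4o3)cc2)ccc1Cl`: 17000 nM
compound 3 `O=S(=O)(Nc1ccc(-c2nc3ccccc3o2)cc1)c1ccc(O)cc1`: 78000 nM

In an assay on cells for inhibition of HSP60/HSP10 (Homo sapiens), with a stated time of 60 min (a lower number here means a stronger inhibitor, a higher number a weaker inhibitor), compound 3 gives the highest number of the three, so it is the weakest inhibitor of the set; compound 1 sits nearest to it and compound 2 furthest, both with lower numbers beyond the scatter.

The step to compound 4 `O=S(=O)(Nc1ccc(-c2nc3ccccc3o2)cc1)c1ccc(Cl)cc1` is chloro in place of hydroxy on an aromatic carbon. Within the data shown here, no measured pair shows exactly this change. Among the measured compounds shown here, the only step available on the sulfonyl aryl side, a 2.5-fold higher number from compound 1 to compound 3 (0.40 log units; beyond the scatter), is a modest one and runs in the direction of a weaker inhibitor when the 4-hydroxyphenyl enters. Compound 1 and compound 2, each carrying a chloro on the sulfonyl aryl, both give lower numbers than compound 3. The change in this assay is therefore expected to be a modest step toward a lower number, of about the size seen for the 1-to-3 step, rather than none.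

Compound 4 is expected at 30000 nM, within 12000 nM to 80000 nM, corresponding to the estimated step of a 2.6-fold lower number from compound 3 to compound 4 (0.41 log units; beyond the scatter).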

Compound 4, half-maximal inhibitory concentration: 61000 nM
Estimate against measurement, compound 4: 2.0-fold (0.31 log units) below, within the range that was stated.
By their numbers in this assay, from the lowest: compounds 2, 1, 4 and 3 (each within the scatter of the next, the first and the last beyond it).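

In this assay, the step with chloro in place of hydroxy on an aromatic carbon, para to a large group, is a 1.3-fold lower number from compound 3 to compound 4 (0.11 log units; within the scatter), so this position does not separate the two groups. The step with 4-chlorophenyl in place of 5-chlorothiophen-2-yl on a sulfonyl sulfur is a 2.0-fold higher number from compound 1 to compound 4 (0.29 log units; within the scatter), so these two sulfonyl groups are not separated either. Among these compounds, the only new step beyond the scatter is a 3.6-fold higher number from compound 2 to compound 4 (0.55 log units; beyond the scatter), with hydrogen in place of nitro on an aromatic carbon, and no available evidence bears on the reason for it.

As far as these compounds go, it remains open whether an amine, a carboxylic acid or a methoxy group at the position para to a large group would give a number apart from those of hydroxy and chloro. From the compounds shown here alone, it also remains open whether nitro gives the same step on a ring without the chloro.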